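The source may report more compounds than this note shows. Statements on the series, on what has been measured and on what is new or still open speak of the compounds shown alone.

Among the compounds with values here, compound 2 `O=C(CN1CCN(c2cccc(Cl)c2)CC1)N(c1ccccc1)c1ccccc1` is the only compound with a number in a functional assay on the whole organism (strain Swiss albino) for inhibition, with Mus musculus as the target, with stated times of 30 min, 10 min and 20 min; a higher number here means that more compound is needed for the effect, a lower number that less compound is needed: compound 2 gives 18 mg/kg. Compound 1 `Cc1cccc(N2CCN(CC(=O)N(c3ccccc3)c3ccccc3)CC2)c1C` sits at a limit of the assay rather than at a number, giving > 30 mg/kg in this assay (the limit of > 30 mg/kg in this assay, at which 1 of the 2 values shown sits). Within the data shown here, the one measured step, an at least 1.6-fold lower number from compound 1 to compound 2 (0.22 log units; that floor lies within the scatter), exchanges an aryl group on the amine nitrogen of the ring and offers only a floor. Compound 3 `O=C(CN1CCN(c2ccc(Cl)c(Cl)c2)CC1)N(c1ccccc1)c1ccccc1` differs from compound 2 by chloro in place of hydrogen on an aromatic carbon, on an aromatic carbon of a six-membered aromatic ring of carbon only, ortho to a chloro group and para to a large group. Among the measured compounds shown here, no measured step touches this carbon, and the one step that exists, from a different ring substituent, has a floor within the scatter, so no step beyond the scatter is expected in this assay. Compound 3 is therefore estimated at 15 mg/kg, between 7 mg/kg and 35 mg/kg. This expectation amounts to a 1.2-fold lower number from compound 2 to compound 3 (0.08 log units; within the scatter).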

Compound 3, dose for half-maximal effect: > 20 mg/kg
Compound 3: a limit, no number (the forecaster's own chance of this, stated with the estimate: 20%); at least 1.3-fold (0.12 log units) between middle value and limit.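

Within the data shown here, with a new chloro group on this aromatic carbon, ortho to a chloro group and para to a large group, this assay gives the first measured step at this position: an at least 1.1-fold higher number from compound 2 to compound 3 (0.04 log units; that floor lies within the scatter). Compound 3 stands at a limit of the assay and not at a number: the limit of > 20 mg/kg in this assay, at which 1 of the 3 values shown sits. The change from 3-chlorophenyl to 3,4-dichlorophenyl is therefore not shown to lower the number needed, though how far the true value of compound 3 lies from that of compound 2 stays unknown, and the step from compound 1 to compound 3 cannot be read.

The compounds shown leave open whether any group on this carbon gives a clearly different number. A fluoro or a methoxy group there, in place of chloro, remains untested in the compounds shown here.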